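This account rests on a few compounds, and the source may have more. Where it says the series, first, only, none or still open, it means among the compounds named here.

Compound 1 `CCCS(=O)(=O)Nc1ccc(F)c(C(=O)c2n[nH]c3ncc(-c4ccccc4C)cc23)c1F`: 7%
Compound 2 `CCCS(=O)(=O)Nc1ccc(F)c(C(=O)c2n[nH]c3ncc(-c4cccc(OC)c4)cc23)c1F`: 6.3%

Among the measured compounds shown here, in an assay for binding affinity to dual specificity mitogen-activated protein kinase kinase 4 (Homo sapiens), read by KINOMEscan, tested at 100 nM (a higher number here means a weaker effect of the compound at the concentration tested, a lower number a stronger effect), compound 2 gives 6.3%, and compound 1 sits within the scatter of it, the only step measured being a number 0.7 percentage points lower from compound 1 to compound 2 (within the scatter). Compound 3 `CCCS(=O)(=O)Nc1ccc(F)c(C(=O)c2n[nH]c3ncc(-c4ccc(F)cc4C)cc23)c1F` differs from compound 2 in one place: 4-fluoro-2-methylphenyl in place of 3-methoxyphenyl on an aromatic carbon. For the measured compounds named here, the single step known exchanges one aryl group for another at the same aromatic carbon, and it stayed within the scatter. The same kind of exchange is made here, so no step beyond the scatter is expected, a number 0.7 percentage points higher from compound 2 to compound 3 (within the scatter). Compound 3 is therefore estimated at 7%, within 2% to 18%.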

Compound 3, a percentage reported as activity, at one concentration (the size of the read-out at that concentration, not a potency): 14%
Estimate against measurement, compound 3: 7 percentage points below, and the stated range covers the measured number.
By their numbers in this assay, from the lowest: compounds 2, 1 and 3 (each within the scatter of the next).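

In this assay, 4-fluoro-2-methylphenyl in place of 3-methoxyphenyl on this aromatic carbon gives a number 7.7 percentage points higher from compound 2 to compound 3 (within the scatter), and fluoro in place of hydrogen on the aryl group gives a number 7 percentage points higher from compound 1 to compound 3 (within the scatter). Across these three compounds, then, neither a new aryl group at this position nor a fluoro on that group moves the number beyond the scatter. Nothing here offers an explanation for these numbers.

On these data alone, all three groups at this position are substituted phenyl rings, so it remains open how an amine or a carboxylic acid would read there.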